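This account rests on a few compounds, and the source may have more. Where it says the series, first, only, none or still open, it means among the compounds named here.

Measured compounds:
compound 1 `Cc1nc(N(C)C(=O)NC(=O)c2c(F)cccc2F)sc1C(=O)N/N=C/c1ccccc1Cl` — > 100 ug/mL in a functional assay on HepG2 cells (Homo sapiens) for inhibition, read by MTT assay, with a stated time of 72 h; a higher number here means a weaker inhibitor, a lower number a stronger inhibitor
compound 2 `CN(C(=O)NC(=O)c1c(Cl)cccc1Cl)c1nc(C(F)(F)F)c(C(=O)N/N=C/c2ccccc2C(F)(F)F)s1` — 8.95 ug/mL in this assay

In this assay compound 1 stands at a limit, > 100 ug/mL, which is a bound of the measurement and not a number (the limit of > 100 ug/mL in this assay, at which 1 of the 2 values shown sits). Going by the values given here, compound 2 gives 8.95 ug/mL in this assay; since compound 2 differs from compound 1 in several places, their two values show only that one reaches a number and the other does not. Compound 3 `Cc1nc(N(C)C(=O)NC(=O)c2c(F)cccc2F)sc1C(=O)N/N=C/c1ccccc1C(F)(F)F` differs from compound 1 by trifluoromethyl in place of chloro on an aromatic carbon, ortho to a large group. Among the compounds with values here, no measured step joins these two, and the step of a number no higher from compound 1 to compound 3 (the limit leaves the size open) is expected to stay within the scatter. Compound 3 is therefore estimated at 100 ug/mL, ranging from 30 ug/mL to 300 ug/mL, most likely again reported only as a limit.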

Compound 3, half-maximal inhibitory concentration: 1.11 ug/mL
Estimate against measurement, compound 3: 90-fold (1.95 log units) above, outside the stated range (below it).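

Replacing chloro with trifluoromethyl on an aromatic carbon, ortho to a large group, gives an at least 90-fold lower number from compound 1 to compound 3 (1.95 log units; beyond the scatter) in this assay. Nothing else in the molecule changes, so this one position is enough to take the series from no measurable number to a measured one, which compound 2, differing in several places, could not show. The full size of the step stays undefined, as compound 1 stands at a limit: the limit of > 100 ug/mL in this assay, at which 1 of the 3 values shown sits.

Going by these compounds, whether a methyl, a methoxy or an amine at this place would act like trifluoromethyl remains open. So does whether chloro in place of trifluoromethyl on that ring of compound 2 would give a step of similar size.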